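This account rests on a few compounds, and the source may have more. Where it says the series, first, only, none or still open, it means among the compounds named here.

Compound 1, `CCCCCCNc1cnc(C(=O)NCc2ccccc2)cn1`: in an ADME assay on MDCK cells (Canis lupus familiaris) for cytotoxicity, read by microscopy, with a stated time of 6 days (on this read-out lower numbers stand for higher toxicity in this test and higher numbers for lower toxicity in this test), compound 1 reaches only the limit > 100000 nM.
Compound 2, `CCCCCCNc1cncc(C(=O)NCc2ccccc2)n1`: in this assay compound 2 gives 20000 nM.

Going by the values given here, the two measured compounds share a core and differ in how the groups are arranged on it; no computed step joins them, so their values are simply set side by side. Compound 1 sits at the limit of > 100000 nM in this assay, at which 1 of the 2 values shown sits, a limit rather than a number. Among the compounds with values here, compound 2 is thus the only compound with a measured number, and it stands alone as the sole numeric point in this assay.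

Compound 3, `CCCCNc1cncc(C(=O)NCc2ccccc2)n1`, has not yet been measured. It is compound 2 with one change: hydrogen in place of ethyl on a saturated chain carbon, four bonds along the chain from a nitrogen on an aromatic ring. Nothing measured here bears on this kind of chain shortening. The expectation rests on the general shape of the data only. A modest step toward lower toxicity is expected, a 2.0-fold higher number from compound 2 to compound 3 (0.30 log units; within the scatter), though it could fall within the scatter. Compound 3 is expected to give about 40000 nM, within a range from 15000 nM to 100000 nM.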

Compound 3, minimum cytotoxic concentration: 100000 nM
For compound 3 the middle estimate is 2.5-fold (0.40 log units) below the measured one; low and high end bracket the measured number.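

Cutting ethyl back to hydrogen on a saturated chain carbon, four bonds along the chain from a nitrogen on an aromatic ring, gives a 5.0-fold higher number from compound 2 to compound 3 (0.70 log units; beyond the scatter) in this assay. Going by these compounds alone, this is the first step measured between two compounds that differ in one place, and it shows that the length of this chain alone can move the read-out beyond the usual scatter, here toward lower toxicity in this test. Compound 1 remains a limit and not a number: the limit of > 100000 nM in this assay, at which 1 of the 3 values shown sits.

A single step cannot tell whether the read-out changes smoothly with chain length or shifts only at one particular length. Going by these compounds, it also remains open whether a shorter propyl chain, a longer octyl chain, or a chain ending in an amine or a carboxylic acid would move the read-out the same way.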